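The source may hold more compounds than are shown below. What is called first, only, known or untested is meant among the compounds shown, and "the series" means these compounds.

Measured so far:
compound 1, `COc1cc(N2C[C@@H]3CCNC[C@@H]32)cnc1Br`: 2980 nM
compound 2, `N#Cc1cncc(N2C[C@@H]3CCNC[C@@H]32)c1`: 2560 nM

In a functional assay on HEK293 cells for agonist activity at Neuronal acetylcholine receptor; alpha3/beta4 (Homo sapiens), read by FLIPR (on this read-out lower numbers stand for an effect already at smaller amounts and higher numbers for an effect only at larger amounts of compound), compound 2 gives 2560 nM and compound 1 gives 2980 nM; the two numbers sit within the scatter of each other, so neither compound can be set apart from the other on this read-out.

Compound 3, `N#Cc1cc(N2C[C@@H]3CCNC[C@@H]32)cnc1Br`, has not been measured. It differs from compound 2 by bromo in place of hydrogen on an aromatic carbon. Among the measured compounds shown here, no measured pair shows this change on its own, and compound 1, which also carries bromo next to the ring nitrogen, gives a number within the scatter of compound 2. No shift beyond the scatter is therefore expected in this assay; the estimated step is a 1.0-fold lower number from compound 2 to compound 3 (0.01 log units; within the scatter). Compound 3 is expected to give about 2500 nM, with a likely range from 1000 nM to 6500 nM.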

Compound 3, half-maximal effective concentration: 794 nM
Compound 3: the middle estimate sits 3.1-fold (0.50 log units) above what was measured; the measured number lies below the stated range.
By their numbers in this assay, from the lowest: compound 3; then compounds 2 and 1 (each within the scatter of the next).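

In this assay, among the compounds shown here, bromo in place of hydrogen on this aromatic carbon, next to the ring nitrogen and ortho to the cyano group, gives a 3.2-fold lower number from compound 2 to compound 3 (0.51 log units; beyond the scatter), the first step beyond the scatter. With bromo at that carbon, cyano in place of methoxy also counts, giving a 3.8-fold lower number from compound 1 to compound 3 (0.57 log units; beyond the scatter). No measurement at hand accounts for either step.

Open, going by these compounds, is whether this step belongs to bromo alone or would also follow with chloro, methyl or an amine on the same carbon.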